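This account rests on a few compounds, and the source may have more. Where it says the series, first, only, none or still open, it means among the compounds named here.

Of the compounds shown here, three that share one core have been measured so far in a functional assay on LOX IMVI cells (Homo sapiens) for cytotoxicity (a lower number here means a stronger inhibitor of growth, a higher number a weaker inhibitor of growth), on this growth read-out. Compound 1 `OCCCCC#Cc1ccccc1C#Cc1cccc(C(F)(F)F)c1` gives 17500 nM and compound 2 `OCCCCC#Cc1ccccc1C#Cc1ccc(O)cc1` gives 13600 nM here. Compound 3 `OCCCCC#Cc1ccccc1C#Cc1ccc(C(F)(F)F)cc1` gives 17100 nM and so stands level with both of them, within the usual scatter of repeated measurements.

The next compound is compound 4 `N#Cc1ccc(C#Cc2ccccc2C#CCCCCO)cc1` and it differs from compound 3 in one place, with cyano in place of trifluoromethyl on an aromatic carbon as the count: cyano in place of trifluoromethyl on an aromatic carbon, para to a large group. Among the measured compounds shown here, one measured step bears directly on this place, namely a 1.3-fold higher number from compound 2 to compound 3 (0.10 log units; within the scatter) for trifluoromethyl in place of hydroxy. That step is small and lies within the scatter. Compound 1 also carries trifluoromethyl, and its number sits within the scatter of compound 3 as well. For the measured compounds named here, this is thin evidence, since one step is all there is and no cyano compound has been measured yet. Even so, no step beyond the scatter is expected in this assay for this swap, and no clear direction can be expected either. The estimate amounts to a 1.1-fold lower number from compound 3 to compound 4 (0.03 log units; within the scatter) as an expected step within the scatter. The estimated value for compound 4 is 16000 nM with an expected range from 8000 nM to 30000 nM in this measurement.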

Compound 4, concentration for 50% growth inhibition: 18300 nM
Estimate against measurement, compound 4: 1.1-fold (0.06 log units) below; the measured number falls inside the stated range.
By their numbers in this assay, from the lowest: compounds 2, 3, 1 and 4 (each within the scatter of the next).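

In this assay, cyano now stands on this aromatic carbon, para to a large group, and replacing trifluoromethyl with it gives a 1.1-fold higher number from compound 3 to compound 4 (0.03 log units; within the scatter) while replacing hydroxy with it gives a 1.3-fold higher number from compound 2 to compound 4 (0.13 log units; within the scatter). Until now only hydroxy and trifluoromethyl could be compared at this place, whereas a third group now shows the same flat picture: cyano has 2 heavy atoms against 4 in trifluoromethyl and adds a triple bond and a hydrogen-bond acceptor, yet neither step leaves the scatter. Nothing available explains why these swaps leave the number within the scatter.

The compounds shown leave open whether an amine, a carboxylic acid or a longer chain on this same aromatic carbon would produce a step beyond the scatter, or whether this place simply has little influence on the number. They also leave open what a change elsewhere would do, such as a shorter or longer version of the hydroxy-ended chain that all four compounds share.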